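Swapping a Methyl for a Cyano on the Aryl Ring

The source may report more compounds than this note shows. Statements on the series, on what has been measured and on what is new or still open speak of the compounds shown alone.

Three compounds have been measured in an assay on cells for inhibition of Palmitoleoyl-protein carboxylesterase NOTUM variant C330S (Homo sapiens), read by fluorescence, with a stated time of 40 min; on this read-out higher numbers stand for weaker inhibition and lower numbers for stronger inhibition:

Compound 1, `Cc1[nH]c(C(F)(F)F)cc1C(=O)O`, gives 6700 nM.
Compound 2, `Cc1cccc(-n2c(C)cc(C(=O)O)c2C)c1`, gives 1500 nM.
Compound 3, `Cc1cc(C(=O)O)c(C)n1-c1ccc(Cl)cc1`, gives 860 nM.

Compound 2 sits in the middle of these three numbers. Its gap to compound 3 lies within the usual scatter of repeated measurements, so the two cannot be told apart on these data. Compound 1, which lacks the aryl ring on the nitrogen of the shared core, gives a number clearly beyond the scatter on the weaker side of compound 2.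

Compound 4, `Cc1cc(C(=O)O)c(C)n1-c1cccc(C#N)c1`, has not yet been measured. It differs from compound 2 in a single place: cyano in place of methyl on an aromatic carbon. Among the measured compounds shown here, no measured pair in this set shows this particular change, so nothing on hand says how large a step it brings. The expectation is a step of a 1.3-fold lower number from compound 2 to compound 4 (0.10 log units; within the scatter) that stays within the scatter, in no firm direction. Compound 4 is therefore estimated at 1200 nM, with a likely range from 400 nM to 3600 nM.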

Compound 4, half-maximal inhibitory concentration: 3100 nM
The estimate for compound 4 lay 2.6-fold (0.41 log units) below the measured number; the measured number falls inside the stated range.
By their numbers in this assay, from the lowest: compounds 3 and 2 (each within the scatter of the next); then compound 4; then compound 1.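

Among the compounds shown here, until now, no pair in the set isolated a single change on the aryl ring, and this pair does. In this assay, cyano in place of methyl on this aromatic carbon, meta to a large group, brings a modest move toward weaker inhibition (a 2.1-fold higher number from compound 2 to compound 4 (0.32 log units; beyond the scatter)), so what sits at this position makes a measurable difference. No measurement on hand explains why the swap acts in this direction.

From the compounds shown here alone, it remains open whether a methoxy group, an amine or a fluorine on this same carbon would give a number closer to that of methyl or that of cyano. Also open, going by these compounds, is whether cyano would bring a similar step on the ring carbon that carries chloro in compound 3.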